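The source may hold more compounds than are shown below. What is called first, only, known or untested is meant among the compounds shown, and "the series" means these compounds.

Working notes on the solubility series.

Compound 3 `CN(C)CCCNc1ccnc2cc(OCc3ccc(F)cc3)ccc12` is the starting point of this step. In a physicochemical assay for solubility (a lower number here means a less soluble compound, a higher number a more soluble compound), compound 3 gives > 10000 ug/mL, which is a limit of the assay and not a number. The two other measured compounds stand in the same place. Compound 1 `C=CCOc1ccc2c(NCCCN(C)C)ccnc2c1` carries an allyloxy chain and a three-carbon diamine side chain; in this assay compound 1 gives > 10000 ug/mL, again a limit. Compound 2 `CCCCCCOc1ccc2c(NCCN(C)C)ccnc2c1` pairs a hexyloxy chain with the shorter diamine side chain; in this assay compound 2 gives > 10000 ug/mL, also a limit. The whole set therefore sits at the limit of > 10000 ug/mL in this assay, at which 3 of the 3 values shown sit.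

For the measured compounds named here, the one step between measured compounds, a step that the two limits leave unreadable from compound 1 to compound 3, cannot be sized, since both ends are limits.

Compound 4 `CN(C)CCNc1ccnc2cc(OCc3ccc(F)cc3)ccc12` differs from compound 3 by dimethylamino in place of (dimethylamino)methyl on a saturated chain carbon, two bonds along the chain from a nitrogen on an aromatic ring. Going by the values given here, no measured step covers this change directly; compound 2, which carries the same shorter side chain on a related core, only shows that such a compound can also reach the limit. Among the compounds with values here, with every value so far at the limit, no step beyond the scatter is expected for a number no higher from compound 3 to compound 4 (the limit leaves the size open). Compound 4 is therefore estimated at 10000 ug/mL, with a range from 4000 ug/mL to 10000 ug/mL, and most likely the assay again reports only a limit.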

Compound 4, solubility: > 10000 ug/mL
Compound 4 ended at the assay's limit; the forecaster's own chance of this, stated with the estimate: 85%; the middle value sits exactly at the limit.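

In this assay compound 4 gives > 10000 ug/mL, a limit and not a number, so neither its step from compound 3 nor its step from compound 2 can be read, and the series stays where it was: the limit of > 10000 ug/mL in this assay, at which 4 of the 4 values shown sit.

The compounds shown leave open how the four rank in this assay and whether any of these changes has a real size there.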